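The source may hold more compounds than are shown below. What is called first, only, known or untested is meant among the compounds shown, and "the series" means these compounds.

Measured compounds:
- Compound 1 `CCCCc1nc2c(-c3ccc(Cl)cc3)n[nH]c2c(=O)n1NC(=O)c1ccccc1`: 93.1%
- Compound 2 `CCCCCc1nc2c(-c3ccc(Cl)cc3)n[nH]c2c(=O)n1NC(=O)c1ccccc1`: 88.7%

In a functional assay on DU-145 cells (Homo sapiens) for cytotoxicity, read by sulforhodamine B assay, with a stated time of 2 days, tested at 100 uM (on this read-out higher numbers stand for more inhibition at the one concentration tested (going by the name of the read-out) and lower numbers for less inhibition), compound 1 gives 93.1% and compound 2 gives 88.7%. Going by the values given here, the only step between them, a number 4.4 percentage points lower from compound 1 to compound 2 (within the scatter), lies within the scatter, so the two numbers cannot be ordered. Among the compounds with values here, compound 2 therefore stands as the lower of two numbers that are, in effect, indistinguishable, with compound 1 as its only neighbour.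

Compound 3 `O=C(Nn1c(CCC2CCCC2)nc2c(-c3ccc(Cl)cc3)n[nH]c2c1=O)c1ccccc1` differs from compound 2 in one place: cyclopentyl in place of propyl on a saturated chain carbon, two bonds along the chain from an aromatic carbon. Within the data shown here, the one measured step, a number 4.4 percentage points lower from compound 1 to compound 2 (within the scatter), concerns the same saturated chain and shows that lengthening it by one carbon changed nothing beyond the scatter. Among the measured compounds shown here, no measured step replaces part of a chain with a ring, so the bearing of the data on compound 3 is indirect. On this basis no step beyond the scatter is expected in this assay for compound 3, though the wider uncertainty of an untested ring is acknowledged. Compound 3 is estimated at 86%, within 70% to 96%, which means an expected step of a number 2.7 percentage points lower from compound 2 to compound 3 (within the scatter).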

Compound 3, a percentage reported as inhibition, at one concentration (the size of the read-out at that concentration, not a potency): 89.6%
Compound 3: the middle estimate sits 3.6 percentage points below what was measured; the measured number falls inside the stated range.
By their numbers in this assay, from the lowest: compounds 2, 3 and 1 (each within the scatter of the next).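

Compound 3 brings the first ring to this place on the chain, a cyclopentyl group on a saturated chain carbon, two bonds along the chain from an aromatic carbon, and in this assay the swap from propyl gives a number 0.9 percentage points higher from compound 2 to compound 3 (within the scatter). Set against the shorter open chain of compound 1, the same place gives a number 3.5 percentage points lower from compound 1 to compound 3 (within the scatter), so at the one concentration tested, this read-out separates the five-membered carbon ring from neither butyl nor pentyl as the full group on the core. No measurement shown here offers a cause for this outcome.

The compounds shown leave open whether a phenyl ring, an amine or a carboxylic acid in this place would give a number that stands apart, as every group here is built of carbon alone. They also leave open whether compound 1, compound 2 and compound 3 would separate at lower concentrations, as a single-concentration reading gives the size of the effect at that concentration and not a potency.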